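A few compounds are considered here, and "the series" means these few. Any claim that something is new, unique, unknown or untested is made for them only; others in the source may bear on it.

Compound 1 `Fc1ccc(Cc2ccc3c(NCCCNCc4ccco4)ccnc3c2)c(Cl)c1` was tested in a physicochemical assay for solubility, with a stated time of 18 h, at pH 7.4 (a higher number here means a more soluble compound, a lower number a less soluble compound), where compound 1 gives 4200 nM. Two close relatives were measured alongside it: compound 2 `COc1ccc(F)cc1CNCCCNc1ccnc2cc(Cc3ccc(F)cc3Cl)ccc12`, which in this assay gives 4200 nM, and compound 3 `COc1ccc(F)cc1CNCCCNc1ccnc2cc(Cc3ccc(C#N)cc3)ccc12`, which gives 4200 nM. Compound 1 stands level with both at the digits shown. The step of no change at the digits printed from compound 1 to compound 2 (within the scatter) puts 5-fluoro-2-methoxyphenyl in place of furan-2-yl on a saturated chain carbon bound to an amine nitrogen, and the step of no change at the digits printed from compound 2 to compound 3 (within the scatter) puts 4-cyanophenyl in place of 2-chloro-4-fluorophenyl on a saturated chain carbon bound to an aromatic carbon; each stays within the scatter. Compound 4 `c1coc(CNCCCNc2ccnc3cc(C4CCCCC4)ccc23)c1` has not yet been measured. It differs from compound 1 by cyclohexyl in place of 2-chloro-4-fluorobenzyl on an aromatic carbon. Of the two measured steps, only the latter alters the group that compound 4 loses, and it gave no change; neither step replaces a whole aromatic group with a saturated ring, so the evidence is indirect. The step expected, no change at the digits printed from compound 1 to compound 4 (within the scatter), is therefore none beyond the scatter. Compound 4 is estimated to give 4200 nM, with a range from 1800 nM to 10000 nM.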

Compound 4, solubility: 4200 nM
For compound 4 middle estimate and measured number coincide at the digits printed, within the range that was stated.
By their numbers in this assay, from the lowest: compounds 1, 2, 3 and 4 (each within the scatter of the next).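

Among the compounds shown here, at this aromatic carbon, the earlier compounds changed only the ring carried on the linking carbon, whereas here the entire 2-chloro-4-fluorobenzyl leaves and a cyclohexyl enters directly on the core. This removes the fluorine, the chlorine and the six-membered aromatic ring of the group, and puts a six-membered non-aromatic ring of carbon only in their place, yet in this assay this larger exchange still reads no change at the digits printed from compound 1 to compound 4 (within the scatter) and so shows that, for this pair, the aromatic character of the group is not needed to hold the number. Nothing measured here gives a reason for this flat result. As far as these compounds go, it remains open whether an amine or a carboxylic acid in place of the cyclohexyl would move the number beyond the scatter. From the compounds shown here alone, whether a longer chain on the other side of the molecule would do so also remains open.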